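The source may hold more compounds than are shown below. What is called first, only, known or untested is meant among the compounds shown, and "the series" means these compounds.

Measured so far:
compound 1 `CC1CCN(c2nc(Cl)nc3c2ncn3Cc2ccc(/C=C/C(=O)Nc3ccccc3N)cc2)CC1`: 8.24%
compound 2 `Cc1ccc(Nc2nc(Cl)nc3c2ncn3Cc2ccc(/C=C/C(=O)Nc3ccccc3N)cc2)cc1`: 31.3%
compound 3 `Nc1ccccc1NC(=O)/C=C/c1ccc(Cn2cnc3c(NC4CCCCC4)nc(Cl)nc32)cc1`: 8.09%

In a functional assay on NCI-H460 cells (Homo sapiens) for antiproliferative activity, read by CCK-8 assay, with a stated time of 72 h, tested at 2 uM (a higher number here means a stronger effect of the compound at the concentration tested, a lower number a weaker effect), compound 3 gives 8.09%, the lowest of the three numbers; its nearest neighbour is compound 1, a gap within the scatter, and its furthest is compound 2.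

The step to compound 4 `Nc1ccccc1NC(=O)/C=C/c1ccc(Cn2cnc3c(NCc4ccccc4)nc(Cl)nc32)cc1` is benzyl in place of cyclohexyl on a nitrogen on an aromatic ring. Of the measured steps, the one that bears most is a number 23.2 percentage points lower from compound 2 to compound 3 (beyond the scatter), where a 4-methylphenyl on that nitrogen stood beyond the scatter above the cyclohexyl; the step of a number 0.2 percentage points lower from compound 1 to compound 3 (within the scatter) shows that swapping one saturated six-membered ring for another changed nothing beyond the scatter. Compound 4 brings back a six-membered aromatic ring of carbon only, but set one carbon further from the nitrogen than in compound 2, so only part of the gain seen in compound 2 is expected. For compound 4 in this assay a modest upward step of a number 7.9 percentage points higher from compound 3 to compound 4 (within the scatter) is expected. The estimate for compound 4 is 16%, with a range from 4% to 34%.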

Compound 4, a percentage reported as inhibition, at one concentration (the size of the read-out at that concentration, not a potency): 4.62%
Compound 4: middle estimate off by 11.4 percentage points, on the high side; the measured number falls inside the stated range.
By their numbers in this assay, from the lowest: compounds 4, 3 and 1 (each within the scatter of the next); then compound 2.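

In this assay, the step of a number 3.5 percentage points lower from compound 3 to compound 4 (within the scatter) shows that a six-membered aromatic ring of carbon only on this nitrogen does not, as benzyl, separate from cyclohexyl. The step of a number 26.7 percentage points lower from compound 2 to compound 4 (beyond the scatter) shows that the aromatic ring alone does not account for the number of compound 2, since 4-methylphenyl and benzyl differ beyond the scatter. With the step of a number 3.6 percentage points lower from compound 1 to compound 4 (within the scatter) also printed as within the scatter, compound 1, compound 3 and compound 4 form one level, and only compound 2 stands apart.

No measurement shown here gives a reason for this difference.

From the compounds shown here alone, whether the number of compound 2 depends on the ring standing directly on the nitrogen, on its methyl or on both stays open, and an unsubstituted phenyl or a pyridinyl on that nitrogen would bear on this.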